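The compounds below may be only part of what the source reports. "The series", "measured", "known", "first", "only" and "open" are said of these compounds alone.

Measured compounds:
- compound 1, `NC(=O)c1c(NC(=O)c2ccccc2Cl)sc2c1CCN(Cc1ccc(Cl)cc1)C2`: 22500 nM
- compound 2, `COc1ccc(NC(=S)N2CCc3c(sc(NC(=O)c4ccccc4Cl)c3C(N)=O)C2)cc1`: 15700 nM
- compound 3, `NC(=O)c1c(NC(=O)c2ccccc2Cl)sc2c1CCN(C(=S)Nc1c(Cl)cccc1Cl)C2`: 3950 nM

All three values come from a functional assay on HL-60 cells (Homo sapiens) for antiproliferative activity, with a stated time of 24 h; on this read-out higher numbers stand for weaker inhibition and lower numbers for stronger inhibition. Compound 3 stands lowest of the three: against compound 2 the step was a 4.0-fold lower number from compound 2 to compound 3 (0.60 log units; beyond the scatter), and against compound 1 it was a 5.7-fold lower number from compound 1 to compound 3 (0.76 log units; beyond the scatter), both beyond the scatter. The step from compound 1 to compound 2, a 1.4-fold lower number from compound 1 to compound 2 (0.16 log units; within the scatter), stays within the scatter, so those two cannot be ordered.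

Compound 4, `NC(=O)c1c(NC(=O)c2ccccc2Cl)sc2c1CCN(C(=S)Nc1cccnc1)C2`, is not yet measured in this assay. Against compound 3 the change is pyridin-3-yl in place of 2,6-dichlorophenyl on an amide-type nitrogen. Going by the values given here, the measured step that bears on it most directly is the one from compound 2 to compound 3, a 4.0-fold lower number from compound 2 to compound 3 (0.60 log units; beyond the scatter), where 2,6-dichlorophenyl on the same amide-type nitrogen gave the lower number relative to 4-methoxyphenyl. Compound 4 gives up the 2,6-dichlorophenyl for pyridin-3-yl, a group that in its count stands closer to the 4-methoxyphenyl of compound 2 than to the dichlorophenyl of compound 3. Among the compounds with values here, no measured pair shows a pyridin-3-yl, so the size of the step is uncertain; the expectation is a higher number for compound 4 than for compound 3, of a size comparable to the reverse of that step, roughly back to the level of compound 2 and compound 1.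

Compound 4 is therefore expected to give about 12000 nM in this assay, with a range from 5000 nM to 30000 nM. This estimate means a step of a 3.0-fold higher number from compound 3 to compound 4 (0.48 log units; beyond the scatter).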

Compound 4, half-maximal inhibitory concentration: 33900 nM
Estimate against measurement, compound 4: 2.8-fold (0.45 log units) below; the measured number lies above the stated range.
By their numbers in this assay, from the lowest: compound 3; then compounds 2, 1 and 4 (each within the scatter of the next, the first and the last beyond it).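

In this assay, going by these compounds alone, on the amide-type nitrogen whose other neighbour is the thiocarbonyl carbon, pyridin-3-yl in place of 2,6-dichlorophenyl gives an 8.6-fold higher number from compound 3 to compound 4 (0.93 log units; beyond the scatter), the largest step so far. Pyridin-3-yl in place of 4-methoxyphenyl gives a 2.2-fold higher number from compound 2 to compound 4 (0.33 log units; beyond the scatter), so all three groups at this position can now be ordered beyond the scatter, with 2,6-dichlorophenyl giving the lowest number, then 4-methoxyphenyl, then pyridin-3-yl. Against the ring-nitrogen substituent of compound 1, a 1.5-fold higher number from compound 1 to compound 4 (0.18 log units; within the scatter) stays within the scatter, as does the step from compound 1 to compound 2, so among the compounds carrying the thiocarbonyl group only compound 3 stands apart from compound 1, and that group alone does not go with a lower number.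

Nothing available explains why the number moves with the group at this position. Still open, as far as these compounds go, is whether the two chlorine atoms account for the low number of compound 3, which plain phenyl, 2-chlorophenyl or 2,6-dimethylphenyl would test, and whether a carbonyl in place of the thiocarbonyl would keep it.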